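The source may hold more compounds than are shown below. What is called first, only, known or untested is meant among the compounds shown, and "the series" means these compounds.

Among the measured compounds shown here, compound 1 `COC(=O)/C=C/c1cccc(N(Cc2ccc(/C=C/c3cccc(F)c3)cc2)C(=O)C2CCCCC2)c1` is one of three compounds measured in an assay on isolated protein with Bile acid receptor (Homo sapiens) as the target (on this read-out higher numbers stand for an effect only at larger amounts of compound and lower numbers for an effect already at smaller amounts), where compound 1 gives 86 nM. Compound 2 `COC(=O)/C=C/c1cccc(N(Cc2ccc(/C=C/c3cccc(F)c3)cc2)C(=O)C(C)C)c1` gives 71 nM in this assay, and the step of a 1.2-fold lower number from compound 1 to compound 2 (0.08 log units; within the scatter) lies within the scatter. For the measured compounds named here, compound 3 `COC(=O)/C=C/c1cccc(N(Cc2ccc(-c3cccc(OC(F)(F)F)c3)cc2)C(=O)C(C)C)c1` gives 247 nM; the step of a 3.5-fold higher number from compound 2 to compound 3 (0.54 log units; beyond the scatter) is the only change beyond the scatter among the three, and it concerns the part attached to the benzyl group rather than the amide. Against compound 3, compound 1 thus stands among the lower numbers, separated from compound 2 only within the scatter.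

Compound 4 `COC(=O)/C=C/c1cccc(N(Cc2ccc(/C=C/C(=O)OCc3ccccc3)cc2)C(=O)C2CCCCC2)c1` differs from compound 1 at that same outer part: benzyloxycarbonyl in place of 3-fluorophenyl on a double-bonded chain carbon bound to a double-bonded chain carbon. Going by the values given here, no measured step covers this exact replacement. Among the compounds with values here, the one step that touches this region, a 3.5-fold higher number from compound 2 to compound 3 (0.54 log units; beyond the scatter), made the number higher, so a change beyond the scatter in the same direction is expected for compound 4, with wide uncertainty: the estimated step is a 2.9-fold higher number from compound 1 to compound 4 (0.46 log units; beyond the scatter). Compound 4 is therefore estimated at 250 nM in this assay, within a range from 80 nM to 800 nM.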

Compound 4, half-maximal effective concentration: > 1000 nM
Compound 4: a limit, no number; the forecaster's own chance of this, stated with the estimate: 5%; middle value at least 4.0-fold (0.60 log units) from the limit.
By their numbers in this assay, from the lowest: compounds 2 and 1 (each within the scatter of the next); then compound 3. At a limit, above all of these: compound 4.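

In this assay, among the compounds shown here, the outer part of the molecule proves far less tolerant of change than the earlier compounds showed: an at least 11-fold higher number from compound 1 to compound 4 (1.06 log units; beyond the scatter) is a large step, whereas a 3.5-fold higher number from compound 2 to compound 3 (0.54 log units; beyond the scatter) was only modest. Both the leaving 3-fluorophenyl and the entering benzyloxycarbonyl hold one six-membered aromatic ring of carbon only, so keeping such a ring on this chain does not by itself keep the number low. The reading for compound 4 is a limit of the assay and not a number: the limit of > 1000 nM in this assay, at which 1 of the 4 values shown sits.

The compounds shown leave open whether a carboxylic acid, a methyl ester or an amide at this place would stay near compound 1. They also leave open whether isopropyl on the carbonyl carbon would behave as cyclohexyl does alongside benzyloxycarbonyl.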